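This account rests on a few compounds, and the source may have more. Where it says the series, first, only, none or still open, it means among the compounds named here.

Measured compounds:
- compound 2 `O=C(NCCCCC(c1ccc(F)cc1)c1ccc(F)cc1)Nc1ccc(Cl)c(C(F)(F)F)c1` — 6.5 nM
- compound 1 `O=C(NCCCCC(c1ccc(F)cc1)c1ccc(F)cc1)Nc1ccc(I)cc1` — "not determined" (no result reported)

Among the compounds with values here, in an ADME assay on isolated protein for inhibition of sodium-dependent dopamine transporter (Homo sapiens) (on this read-out higher numbers stand for weaker inhibition and lower numbers for stronger inhibition), compound 2 gives 6.5 nM; it carries the only number in this set, since compound 1 gives "not determined" (no result reported). Compound 3 `CC(=O)Nc1cc(NC(=O)NCCCCC(c2ccc(F)cc2)c2ccc(F)cc2)ccc1Cl` differs from compound 2 by one change: acetamido in place of trifluoromethyl on an aromatic carbon. Without a measured pair to set a scale for the size of such a step, the change is estimated as a moderate weakening of inhibition, a step of a 3.1-fold higher number from compound 2 to compound 3 (0.49 log units; beyond the scatter). Compound 3 is therefore estimated at 20 nM, within a range from 5 nM to 100 nM.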

Compound 3, inhibition constant: 609 nM
Compound 3: middle estimate off by 30-fold (1.48 log units), on the low side, outside the stated range (above it).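

In this assay, acetamido in place of trifluoromethyl on an aromatic carbon ortho to a chloro group gives a 94-fold higher number from compound 2 to compound 3 (1.97 log units; beyond the scatter) and thus much weaker inhibition. This position therefore does not treat the two groups alike, although each has 4 heavy atoms and neither brings a ring. Acetamido does bring a hydrogen-bond donor and a hydrogen-bond acceptor, which trifluoromethyl does not, but this single step cannot separate their share from that of the other differences.

On these data alone, how an amine, a methoxy group or a nitrile on this carbon would compare remains open. Nothing at hand explains the size of this step.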